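This account rests on a few compounds, and the source may have more. Where it says the series, first, only, none or still open, it means among the compounds named here.

Among the three measured compounds, compound 2 `Cc1ccc(-n2cc(-c3ccc(CN4CCN(C)CC4)c(C(F)(F)F)c3)nn2)cc1Nc1nccc(-c2cccnc2)n1` stands lowest in a functional assay on K562 cells (Homo sapiens) for inhibition, read by MTT assay, with a stated time of 72 h (on this read-out lower numbers stand for stronger inhibition and higher numbers for weaker inhibition), where compound 2 gives 40 nM. Compound 1 `Cc1ccc(-n2cc(-c3ccc(CN4CCN(C)CC4)cc3)nn2)cc1Nc1nccc(-c2cccnc2)n1` gives 790 nM in this assay, and compound 3 `Cc1ccc(-n2cc(-c3cc(C(F)(F)F)cc(C(F)(F)F)c3)nn2)cc1Nc1nccc(-c2cccnc2)n1` gives 2650 nM. Among the measured compounds shown here, the one measured single-point step, a 20-fold lower number from compound 1 to compound 2 (1.30 log units; beyond the scatter), placed trifluoromethyl in place of hydrogen on an aromatic carbon. Compound 4 `Cc1ccc(-n2cc(-c3ccc(C)c(C(F)(F)F)c3)nn2)cc1Nc1nccc(-c2cccnc2)n1` differs from compound 2 by hydrogen in place of 4-methylpiperazin-1-yl on a saturated chain carbon bound to an aromatic carbon. For the measured compounds named here, no measured step removes this group alone; compound 3, which also lacks it but carries two trifluoromethyl groups, gives the highest number of the three. Because compound 3 gives 2650 nM, compound 4 is expected to give a higher number than compound 2, a step of a 6.3-fold higher number from compound 2 to compound 4 (0.80 log units; beyond the scatter). The estimate for compound 4 is 250 nM, within 60 nM to 1200 nM.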

Compound 4, half-maximal inhibitory concentration: > 30000 nM
Compound 4 was reported as a limit; the forecaster's own chance of this, stated with the estimate: 5%; middle value at least 120-fold (2.07 log units) away from the limit.
By their numbers in this assay, from the lowest: compound 2; then compound 1; then compound 3. At a limit, above all of these: compound 4.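

With trifluoromethyl kept in place, taking 4-methylpiperazin-1-yl off the saturated chain carbon gives an at least 750-fold higher number from compound 2 to compound 4 (2.87 log units; beyond the scatter) in this assay. This is the first single change shown at this position, and it reveals that in this pair the read-out depends heavily on that group, which the earlier step could not show. The value for compound 4 is a limit: the limit of > 30000 nM in this assay, at which 1 of the 4 values shown sits.

The compounds shown leave open whether the whole ring is needed or a smaller group would serve. A dimethylamino group or a morpholine ring on the same carbon would test this.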